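The compounds below may be only part of what the source reports. "The series", "measured", "known", "first", "only" and "open" are said of these compounds alone.

Compound 2 `O=C1Cc2cc(NC(=O)[C@H]3CCCN3C(=O)C3(c4cccc(Cl)c4)CCCC3)ccc2N1` stands second among the three numbers in an assay on isolated protein for inhibition of histone acetyltransferase p300 (Homo sapiens), with a stated time of 60 min (a lower number here means a stronger inhibitor, a higher number a weaker inhibitor), where compound 2 gives 0.794 nM. Compound 1 `O=C(Nc1ccc2[nH]ccc2n1)[C@H]1CCCN1C(=O)C1(c2cccc(Cl)c2)CCCC1` gives 0.159 nM, and the step of a 5.0-fold higher number from compound 1 to compound 2 (0.70 log units; beyond the scatter) came from swapping only the group on the amide-type nitrogen, so that position has already moved the number once. Going by the values given here, compound 3 `COc1ccc(NC(=O)[C@H]2CCN2C(=O)C2(c3ccc(Cl)cc3)CCCC2)cc1` gives 39.8 nM, but it differs from compound 2 in more than one place and offers no single step. Compound 4 `CNC(=O)c1cccc(NC(=O)[C@H]2CCCN2C(=O)C2(c3cccc(Cl)c3)CCCC2)c1` carries a group of 10 heavy atoms (8 carbon, 1 nitrogen, 1 oxygen; one six-membered aromatic ring of carbon only) in place of a group of 10 heavy atoms (8 carbon, 1 nitrogen, 1 oxygen; one five-membered non-aromatic ring with 1 hetero atom, one six-membered aromatic ring of carbon only), on an amide-type nitrogen. Among the compounds with values here, no measured step covers this exact swap; the one related step went beyond the scatter, so a modest loss is expected, a 5.0-fold higher number from compound 2 to compound 4 (0.70 log units; beyond the scatter). Compound 4 is estimated at 4 nM, likely between 0.8 nM and 20 nM.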

Compound 4, half-maximal inhibitory concentration: 1260 nM
Estimate against measurement, compound 4: 320-fold (2.50 log units) below, outside the stated range (above it).
By their numbers in this assay, from the lowest: compound 1; then compound 2; then compound 3; then compound 4.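

The 3-(methylcarbamoyl)phenyl group matches the group it replaces in heavy atoms, hydrogen-bond donors and hydrogen-bond acceptors, yet the result is a 1600-fold higher number from compound 2 to compound 4 (3.20 log units; beyond the scatter), and against the best compound it is a 7900-fold higher number from compound 1 to compound 4 (3.90 log units; beyond the scatter). This position on the amide-type nitrogen can therefore move the number far more than the first step showed, and those matching counts do not predict the outcome. Nothing measured here explains the loss. From the compounds shown here alone, it remains open whether the loss comes from the methylcarbamoyl group itself or from losing the five-membered ring, and whether a carboxylic acid or an amine in its place would restore the number.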